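The compounds below may be only part of what the source reports. "The series", "measured", "known", "first", "only" and "open" are said of these compounds alone.

Measured so far:
- compound 1, `OCc1cn([C@@H]2O[C@H](CO)[C@@H](O)[C@H]2O)nn1`. In a functional assay on MOLT-4 cells (Homo sapiens) (on this read-out lower numbers stand for stronger inhibition and higher numbers for weaker inhibition), compound 1 reaches only the limit > 200000 nM, which is a limit of the assay and not a number.
- compound 2, `OC[C@H]1O[C@@H](n2cc(-c3ccccn3)nn2)[C@H](O)[C@@H]1O`. In this assay compound 2 gives 170000 nM.

Among the measured compounds shown here, compound 2 is therefore the only measured number in this assay; the other entry is a limit, (the limit of > 200000 nM in this assay, at which 1 of the 2 values shown sits). For the measured compounds named here, the one measured step, an at least 1.1-fold lower number from compound 1 to compound 2 (0.07 log units; that floor lies within the scatter), is a floor that sits within the scatter, so the two compounds cannot be ordered.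

Compound 3, `OC[C@H]1O[C@@H](n2cc(-c3ccsc3)nn2)[C@H](O)[C@@H]1O`, differs from compound 2 in one place: thiophen-3-yl in place of pyridin-2-yl on an aromatic carbon. Going by the values given here, the only step with a bearing on an aryl group at this position is the one from compound 1 to compound 2, and it gives no resolved size. With no step beyond the scatter on record, no change beyond the scatter is expected in this assay for compound 3; the expected change is a 1.2-fold higher number from compound 2 to compound 3 (0.07 log units; within the scatter). Compound 3 is estimated at 200000 nM, within 80000 nM to 500000 nM. Given that compound 1 sits at a limit, a limit-only result for compound 3 is a real possibility.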

Compound 3, half-maximal inhibitory concentration: 126000 nM
For compound 3 the middle estimate is 1.6-fold (0.20 log units) above the measured one; the range from low to high includes it.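

In this assay, thiophen-3-yl in place of pyridin-2-yl on the aromatic carbon gives a 1.3-fold lower number from compound 2 to compound 3 (0.13 log units; within the scatter), so a five-membered aromatic ring with one hetero atom and a six-membered aromatic ring with one hetero atom cannot be told apart at this position. The comparison with hydroxymethyl at the same carbon gives an at least 1.5-fold lower number from compound 1 to compound 3 (0.20 log units; that floor lies within the scatter), so the data do not order thiophen-3-yl against hydroxymethyl, just as they did not order pyridin-2-yl against it. Compound 1 remains a limit of the assay and not a number: the limit of > 200000 nM in this assay, at which 1 of the 3 values shown sits.

Still open, as far as these compounds go, is whether any group on this aromatic carbon moves the number beyond the scatter, for example a phenyl ring bearing an amine or a carboxylic acid, or a longer alkyl chain in place of the aromatic ring. The compounds shown also change only this one position, so they leave open how the number responds to any change on the shared core.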